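A few compounds are considered here, and "the series" means these few. Any claim that something is new, unique, unknown or untested is made for them only; others in the source may bear on it.

In a functional assay on Lewis lung carcinoma cells for cytotoxicity against Lewis lung carcinoma cell line (Mus musculus), read by MTT assay, with a stated time of 72 h (a lower number here means a stronger inhibitor, a higher number a weaker inhibitor), compound 1 `O=C1/C(=C/c2ccccc2F)COC/C1=C\c1ccc(Cl)cc1Cl` gives 29400 nM and compound 2 `COc1ccc(OC)c(/C=C2\COC/C(=C\c3ccccc3F)C2=O)c1` gives 15100 nM so far. These two values lie within the usual scatter of each other, so compound 2 stands level with compound 1 and the pair cannot be ranked.

Compound 3 `COc1ccccc1/C=C1\COC/C(=C\c2ccccc2F)C1=O` has not yet been measured. It departs from compound 2 in one place, with hydrogen in place of methoxy on an aromatic carbon, and hydrogen in place of methoxy on an aromatic carbon sums up the whole difference. Among the measured compounds shown here, no measured pair shows this change on its own. For the measured compounds named here, the only guide is that compound 1 at 29400 nM and compound 2 at 15100 nM stay within the scatter although they differ in more than one place. No step beyond the scatter is therefore expected in this assay and neither direction can be favoured. The estimated step of a 1.2-fold higher number from compound 2 to compound 3 (0.08 log units; within the scatter) is expected to stay within the scatter as well. For compound 3 the expected value is 18000 nM with an estimated range from 7000 nM to 45000 nM for most repeat measurements.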

Compound 3, half-maximal inhibitory concentration: 15400 nM
Compound 3: middle estimate off by 1.2-fold (0.07 log units), on the high side, and the stated range covers the measured number.
By their numbers in this assay, from the lowest: compounds 2, 3 and 1 (each within the scatter of the next).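

In this assay the step of a 1.0-fold higher number from compound 2 to compound 3 (0.01 log units; within the scatter) comes from hydrogen in place of methoxy on an aromatic carbon, at the place meta to a large group and para to a methoxy group. Among the compounds shown here, this is the first pair to differ by this change alone, and it shows that the number does not respond measurably to this methoxy group. The two values cannot be told apart. The step of a 1.9-fold lower number from compound 1 to compound 3 (0.28 log units; within the scatter) with 2-methoxyphenyl in place of 2,4-dichlorophenyl also gives no ranking, and nothing at hand explains why these numbers sit so close together.

Still open, from the compounds shown here alone, is whether any group at this aromatic carbon can move the number beyond the scatter, for example an amine, a carboxylic acid or a longer chain such as butoxy. The compounds shown also leave open what happens with hydrogen in place of the remaining methoxy group of compound 3, so the role of that group in this assay is unknown.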